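This account rests on a few compounds, and the source may have more. Where it says the series, first, only, none or still open, it means among the compounds named here.

Compound 1 `CC(C)N(C(=O)CCNC(=O)c1ccc(S(C)(=O)=O)c([N+](=O)[O-])c1)C(C)C` opens the series. In an ADME assay on HepG2 cells (Homo sapiens) for cytotoxicity, read by CellTiter-Glo and ATP content, with a stated time of 72 h (a higher number here means that more compound is needed for the effect, a lower number that less compound is needed), compound 1 gives > 27000 nM, which is a limit of the assay and not a number. Compound 2 `CS(=O)(=O)c1ccc(C(=O)NCC(=O)N2CCc3ccccc3C2)cc1[N+](=O)[O-]` is the second measured member. In this assay compound 2 gives > 27000 nM, again a limit rather than a number. Both values sit at the limit of > 27000 nM in this assay, at which 2 of the 2 values shown sit, so compound 1 stands exactly where the whole measured set stands. Compound 3 `CS(=O)(=O)c1ccc(C(=O)NCCCC(=O)N2CCCCC2)cc1[N+](=O)[O-]` differs from compound 1 by ((piperidin-1-yl)carbonyl)methyl in place of diisopropylcarbamoyl on a saturated chain carbon, two bonds along the chain from an amide-type nitrogen. No step beyond the scatter is expected in this assay. The expected step is a step that the limit leaves unreadable from compound 1 to compound 3. Compound 3 is expected at 30000 nM, within 15000 nM to 60000 nM, most likely reported again as a limit.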

Compound 3, half-maximal effective concentration: > 27000 nM
Compound 3: only a limit was reported; the forecaster's own chance of this, stated with the estimate: 85%; the middle value is on the limit's open side.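

Compound 3 in this assay gives > 27000 nM and this is a limit, not a number, so no step can be read between compound 1 and compound 3. The compounds shown leave open the concentration at which any of them reaches the half-maximal effect, since all stand at one limit: the limit of > 27000 nM in this assay, at which 3 of the 3 values shown sit.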